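The source may report more compounds than this note shows. Statements on the series, on what has been measured and on what is new or still open speak of the compounds shown alone.

Measured so far in an assay on membranes from striatum (strain Sprague-Dawley) for displacement of a labelled ligand from sodium-dependent dopamine transporter (Rattus norvegicus), read by scintillation counting, with a stated time of 120 min; on this read-out higher numbers stand for weaker inhibition and lower numbers for stronger inhibition:

compound 1 `OC(Cc1ccccc1)CN1CCC(NCCSC(c2ccc(F)cc2)c2ccc(F)cc2)CC1` gives 31.4 nM
compound 2 `O=C(c1ccccc1)N1CCC(NCCSC(c2ccc(F)cc2)c2ccc(F)cc2)CC1` gives 4.51 nM
compound 3 `O=C(c1cc2ccccc2[nH]1)N1CCC(NCCSC(c2ccc(F)cc2)c2ccc(F)cc2)CC1` gives 177 nM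

Compound 3 carries the highest number of the three. The step of a 39-fold higher number from compound 2 to compound 3 (1.59 log units; beyond the scatter) is the largest gap in the set, and the step of a 5.6-fold higher number from compound 1 to compound 3 (0.75 log units; beyond the scatter) is smaller but still clear. Among the measured steps, a 7.0-fold lower number from compound 1 to compound 2 (0.84 log units; beyond the scatter) shows that an acyl group on the ring nitrogen can sit well below an alkyl one, whereas the indole-bearing acyl group of compound 3 sits far above both.

Compound 4 `CC(C)(C)CN1CCC(NCCSC(c2ccc(F)cc2)c2ccc(F)cc2)CC1` is not yet measured. The change is neopentyl in place of (1H-indol-2-yl)carbonyl on an amine nitrogen in a ring. Going by the values given here, the steps that bear on it are the two that swap the group on the ring nitrogen, since neither a five-membered aromatic ring nor a carbonyl remains after the change. Both point away from the number of compound 3, so a downward step is expected, probably nearer the size of the smaller of the two than the larger. The estimated step is a 5.9-fold lower number from compound 3 to compound 4 (0.77 log units; beyond the scatter). For compound 4 the expected value is 30 nM, with a range from 8 nM to 110 nM.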

Compound 4, inhibition constant: 279 nM
The estimate for compound 4 lay 9.3-fold (0.97 log units) below the measured number, outside the stated range (above it).
By their numbers in this assay, from the lowest: compound 2; then compound 1; then compounds 3 and 4 (each within the scatter of the next).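

At the amine nitrogen in the ring, neopentyl gives a 62-fold higher number from compound 2 to compound 4 (1.79 log units; beyond the scatter) and an 8.9-fold higher number from compound 1 to compound 4 (0.95 log units; beyond the scatter), so this group, with no ring and no hydrogen-bond donor or acceptor, does not match benzoyl or 2-hydroxy-3-phenylpropyl here. Against (1H-indol-2-yl)carbonyl it gives a 1.6-fold higher number from compound 3 to compound 4 (0.20 log units; within the scatter), so an acyl and an alkyl group land together, and acyl versus alkyl does not by itself order this position: compound 2 and compound 3 are both acyl, yet they stand at opposite ends of the series, with neopentyl level with compound 3. No measurement at hand explains these steps.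

The compounds shown do not separate the part played by the carbonyl of compound 2 from that of its phenyl ring, which a benzyl group on the same nitrogen would do. A pivaloyl group would likewise pair directly with neopentyl.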